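A few compounds are considered here, and "the series" means these few. Any claim that something is new, unique, unknown or untested is made for them only; others in the source may bear on it.

Measured compounds in an assay on microsomes from liver for inhibition of 3-hydroxy-3-methylglutaryl-coenzyme A reductase (Rattus norvegicus); on this read-out lower numbers stand for stronger inhibition and higher numbers for weaker inhibition:
- compound 1 `CC(C)c1c(C(=O)N(C)Cc2ccccc2)nn(-c2ccc(F)cc2)c1OC[C@@H](O)C[C@@H](O)CC(=O)O`: 5.2 nM
- compound 2 `Cc1ccc(CN(C)C(=O)c2nn(-c3ccc(F)cc3)c(OC[C@@H](O)C[C@@H](O)CC(=O)O)c2C(C)C)cc1`: 37 nM
- compound 3 `Cc1ccccc1CNC(=O)c1nn(-c2ccc(F)cc2)c(OC[C@@H](O)C[C@@H](O)CC(=O)O)c1C(C)C`: 17 nM

Compound 1 has the lowest number of the three. Its nearest neighbour is compound 3, reached by a 3.3-fold higher number from compound 1 to compound 3 (0.51 log units; beyond the scatter); the furthest is compound 2, reached by a 7.1-fold higher number from compound 1 to compound 2 (0.85 log units; beyond the scatter). Between compounds 2 and 3 the data show a 2.2-fold lower number from compound 2 to compound 3 (0.34 log units; beyond the scatter).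

The next compound, compound 4 `COc1ccccc1CNC(=O)c1nn(-c2ccc(F)cc2)c(OC[C@@H](O)C[C@@H](O)CC(=O)O)c1C(C)C`, is not yet measured. Against compound 1 it carries one change: (2-methoxybenzyl)amino in place of benzyl(methyl)amino on a carbonyl carbon. Among the measured compounds shown here, the step that bears most on this is the one from compound 1 to compound 3, where the same move from benzyl(methyl)amino to a secondary amide with a substituted benzyl group gave a 3.3-fold higher number from compound 1 to compound 3 (0.51 log units; beyond the scatter). The step from compound 1 to compound 2 adds that a substituent on the benzyl ring also raised the number. Compound 4 is therefore expected to sit modestly above compound 1 in this assay, an estimated 3.5-fold higher number from compound 1 to compound 4 (0.54 log units; beyond the scatter). The estimate for compound 4 is 18 nM, with a range from 6 nM to 55 nM.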

Compound 4, half-maximal inhibitory concentration: 22 nM
The estimate for compound 4 lay 1.2-fold (0.09 log units) below the measured number; low and high end bracket the measured number.
By their numbers in this assay, from the lowest: compound 1; then compounds 3, 4 and 2 (each within the scatter of the next, the first and the last beyond it).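

In this assay, a second secondary amide with a substituted benzyl group stays on the weaker side of the benzyl(methyl)amino amide (a 4.2-fold higher number from compound 1 to compound 4 (0.63 log units; beyond the scatter)), so compounds 3 and 4 now agree in direction at this carbonyl carbon. Exchanging methyl for methoxy on the benzyl ring gives no readable change (a 1.3-fold higher number from compound 3 to compound 4 (0.11 log units; within the scatter)), and the methyl(4-methylbenzyl)amino amide cannot be separated from the (2-methoxybenzyl)amino amide either (a 1.7-fold lower number from compound 2 to compound 4 (0.23 log units; within the scatter)). No measurement offered here gives a reason for these steps.

The compounds shown leave open how the rise from compound 1 divides between the missing methyl on the amide nitrogen and the added group on the benzyl ring, a split that a plain benzylamino amide would address. Also open, from the compounds shown here alone, is how a chloro or hydroxy group on that ring would read.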